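Swapping octyl for 4-butylphenyl on a triple-bonded carbon

This account rests on a few compounds, and the source may have more. Where it says the series, first, only, none or still open, it means among the compounds named here.

Compound 1 `CCCCCCCCC#Cc1cn(C/C=C\CN2C(=O)c3ccccc3C2=O)c(=O)[nH]c1=O`: 59000 nM
Compound 2 `CCCCCCCCC#Cc1cn(C/C=C/CN2C(=O)c3ccccc3C2=O)c(=O)[nH]c1=O`: > 100000 nM, a limit of the assay
Compound 3 `CCCCCC#Cc1cn(C/C=C/CN2C(=O)c3ccccc3C2=O)c(=O)[nH]c1=O`: 91000 nM

In a functional assay on HeLa cells (Homo sapiens) for antiproliferative activity, read by MTT assay, with a stated time of 3 days (a higher number here means a weaker inhibitor, a lower number a stronger inhibitor), compound 1 gives the lowest of the two numbers shown, and compound 3 sits within the scatter of it. Compound 4 `CCCCc1ccc(C#Cc2cn(C/C=C\CN3C(=O)c4ccccc4C3=O)c(=O)[nH]c2=O)cc1` differs from compound 1 by 4-butylphenyl in place of octyl on a triple-bonded carbon. Within the data shown here, no measured step matches this change. The step of an at least 1.6-fold higher number from compound 1 to compound 2 (0.22 log units; that floor lies within the scatter) alters only the drawn configuration, and the step of an at least 1.0-fold lower number from compound 2 to compound 3 (0.04 log units; that floor lies within the scatter) only shortens the chain; both stay within the scatter. Replacing a flexible octyl chain with a ring is therefore not covered by any measured step, and no direction can be taken from these data. For compound 4 the estimate is 55000 nM, from 15000 nM to 200000 nM, a step of a 1.1-fold lower number from compound 1 to compound 4 (0.03 log units; within the scatter) expected to lie within the scatter.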

Compound 4, half-maximal inhibitory concentration: 85000 nM
The estimate for compound 4 lay 1.5-fold (0.19 log units) below the measured number, and the stated range covers the measured number.
By their numbers in this assay, from the lowest: compounds 1, 4 and 3 (each within the scatter of the next). At a limit, above all of these: compound 2.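

In this assay the swap gives a 1.4-fold higher number from compound 1 to compound 4 (0.16 log units; within the scatter), so on this triple-bonded carbon a group with a six-membered aromatic ring can replace a ring-free chain with no change beyond the scatter. The earlier compounds shown here carried only ring-free chains here, so they could not show this. Nothing measured here gives a cause for this step.

Going by these compounds, it remains open whether an amine or a carboxylic acid in place of octyl would give a step beyond the scatter. Also open, on these data alone, is how 4-butylphenyl behaves with the double bond drawn E, as in compound 2.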